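From a bromophenyl to a fluorophenyl on the shared core

The compounds below may be only part of what the source reports. "The series", "measured", "known", "first", "only" and "open" are said of these compounds alone.

Compound 2 `Brc1ccc(-c2cn3ccnc3c(-c3ccc4ncn(C5CCCCC5)c4c3)n2)cc1` stands lowest of the two numbers measured in a functional assay on OVCAR-8 cells (Homo sapiens) for inhibition, read by sulforhodamine B assay, with a stated time of 48 h, tested at 10 uM; on this read-out higher numbers stand for more inhibition at the one concentration tested (going by the name of the read-out) and lower numbers for less inhibition: compound 2 gives 13.2%, while compound 1 `O=Cc1ccc(-c2cn3ccnc3c(-c3ccc4ncn(C5CCCCC5)c4c3)n2)cc1` gives 44%. Within the data shown here, the only measured step, a number 30.8 percentage points lower from compound 1 to compound 2 (beyond the scatter), shows that exchanging one group on the pendant ring can move the read-out far beyond the scatter. Compound 3 `Fc1ccccc1-c1cn2ccnc2c(-c2ccc3ncn(C4CCCCC4)c3c2)n1` differs from compound 2 by 2-fluorophenyl in place of 4-bromophenyl on an aromatic carbon. Among the measured compounds shown here, no step with a fluoro group is measured, so the direction rests on the size of the one known step alone. Compound 3 is expected to give 25%, between 5% and 50%. The expected step is a number 11.8 percentage points higher from compound 2 to compound 3 (beyond the scatter), which is close to the scatter.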

Compound 3, a percentage reported as inhibition, at one concentration (the size of the read-out at that concentration, not a potency): 14.1%
Beside the measured number, compound 3's estimate is 10.9 percentage points above it; low and high end bracket the measured number.
By their numbers in this assay, from the lowest: compounds 2 and 3 (each within the scatter of the next); then compound 1.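

Replacing 4-bromophenyl with 2-fluorophenyl at this position gives a number 0.9 percentage points higher from compound 2 to compound 3 (within the scatter) in this assay, so these two halogen-bearing rings cannot be told apart here, although both the halogen and its place on the ring differ. The other comparison gives a number 29.9 percentage points lower from compound 1 to compound 3 (beyond the scatter), so compound 1 with its 4-formylphenyl stands apart from both halogen-bearing compounds. No evidence is available on why these rings read as they do. The compounds shown leave open whether the formyl group itself or its place on the ring sets compound 1 apart, and how a carboxylic acid or an amine on the pendant ring would read.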